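Swapping Cyclohexyl for 4-Nitrophenyl: Expected Antiproliferative Potency

The compounds below may be only part of what the source reports. "The series", "measured", "known", "first", "only" and "open" are said of these compounds alone.

Compound 1 `CCCCCCCCCCCCCCCCCCNC(=O)[C@H]1CSC(C2CCCCC2)N1`: 12800 nM
Compound 2 `CCCCCCCCCCCCCCCCCCNC(=O)[C@H]1CSC(Cc2ccccc2)N1`: 4400 nM

Within the data shown here, in a functional assay on LNCaP cells (Prostate gland, Homo sapiens) for antiproliferative activity, read by sulforhodamine B assay (on this read-out lower numbers stand for stronger inhibition and higher numbers for weaker inhibition), compound 1 stands highest of the two numbers; the single measured step, a 2.9-fold lower number from compound 1 to compound 2 (0.46 log units; beyond the scatter), is modest. Compound 3 `CCCCCCCCCCCCCCCCCCNC(=O)[C@H]1CSC(c2ccc([N+](=O)[O-])cc2)N1` has not been measured. It differs from compound 1 by 4-nitrophenyl in place of cyclohexyl on a saturated ring carbon. Among the measured compounds shown here, the only step that bears on this change is a 2.9-fold lower number from compound 1 to compound 2 (0.46 log units; beyond the scatter), in which the same cyclohexyl was also replaced, and it lowered the number modestly. A step of similar size and direction is therefore expected, a 2.6-fold lower number from compound 1 to compound 3 (0.41 log units; beyond the scatter). The estimate for compound 3 is 5000 nM, with a range from 2000 nM to 16000 nM.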

Compound 3, half-maximal inhibitory concentration: 8400 nM
Beside the measured number, compound 3's estimate is 1.7-fold (0.23 log units) below it; the range from low to high includes it.
By their numbers in this assay, from the lowest: compounds 2, 3 and 1 (each within the scatter of the next, the first and the last beyond it).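

In this assay, 4-nitrophenyl on this saturated ring carbon gives a 1.5-fold lower number from compound 1 to compound 3 (0.18 log units; within the scatter) and a 1.9-fold higher number from compound 2 to compound 3 (0.28 log units; within the scatter). Compound 3 therefore cannot be separated from either compound 1 or compound 2, even though those two differ beyond the scatter, so this position tolerates an aromatic ring attached directly as well as cyclohexyl and benzyl. No measurement shown here accounts for this result. On these data alone, whether plain phenyl would read like compound 3 remains open, as does whether an amine or a carboxylic acid at this ring carbon would move the number beyond the scatter.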